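The compounds below may be only part of what the source reports. "The series", "measured", "known", "first", "only" and "open" are said of these compounds alone.

Measured compounds:
compound 1, `FC(F)(F)c1ccccc1NC(=S)N/N=C/c1ccc2ccccc2n1`: 13200 nM
compound 2, `NC(=S)N/N=C/c1cc2ccccc2s1`: > 100000 nM

Compound 1 holds the only number shown in a functional assay on HL-60 cells (Homo sapiens) for antiproliferative activity, read by sulforhodamine B assay, with a stated time of 72 h (on this read-out lower numbers stand for stronger inhibition and higher numbers for weaker inhibition), where compound 1 gives 13200 nM. Compound 2 returns only > 100000 nM in this assay, a limit of the assay and not a number, sitting at the limit of > 100000 nM in this assay, at which 1 of the 2 values shown sits. Going by the values given here, the two values therefore give no measured step between compound 1 and compound 2.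

Compound 3, `S=C(N/N=C/c1ccc2ccccc2n1)Nc1ccccc1Br`, differs from compound 1 as bromo in place of trifluoromethyl on an aromatic carbon. Among the compounds with values here, no measured pair in this assay shows a change of this kind, so the size of the step rests on no precedent. The expected step from compound 1 to compound 3 in this assay is a 1.1-fold higher number from compound 1 to compound 3 (0.06 log units; within the scatter), a change not beyond the usual scatter and with no direction claimed. Compound 3 is estimated at 15000 nM in this assay, expected to fall between 5000 nM and 45000 nM.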

Compound 3, half-maximal inhibitory concentration: > 100000 nM
Compound 3: a limit, no number; the forecaster's own chance of this, stated with the estimate: 10%; middle value at least 6.6-fold (0.82 log units) away from the limit.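

In this assay, going by these compounds alone, the change at this aromatic carbon is the first measured step, and it is not neutral: an at least 7.5-fold higher number from compound 1 to compound 3 (0.87 log units; beyond the scatter). Compound 3 gives > 100000 nM, a limit and not a number, so only a lower bound on the size of this step can be read. Within the core of compound 1, the antiproliferative read-out therefore depends on which of these two groups occupies this one carbon, and compound 1 still holds the only number: the limit of > 100000 nM in this assay, at which 2 of the 3 values shown sit.

From the compounds shown here alone, it remains open whether trifluoromethyl is specifically required here, or whether a chloro, methoxy or amine group on the same carbon would keep a measurable value. The compounds shown also leave open whether any group on this carbon gives a lower number than compound 1.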